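Replacing nitro with amino in the hydroxy series

The source may hold more compounds than are shown below. What is called first, only, known or untested is meant among the compounds shown, and "the series" means these compounds.

In a functional assay on MCF7 cells (Homo sapiens) for cytotoxicity, read by MTT assay, with a stated time of 6 days (a lower number here means that less compound is needed, a higher number that more compound is needed for the effect), compound 1 (`O=c1cc(-c2ccc([N+](=O)[O-])cc2)oc2cc(O)ccc12`) gives > 25 ug/mL, which is a limit of the assay and not a number. Compound 2 (`O=c1cc(-c2ccc([N+](=O)[O-])cc2)oc2c(O)c(O)ccc12`) gives 4.69 ug/mL in this assay. For the measured compounds named here, the only measured step is an at least 5.3-fold lower number from compound 1 to compound 2 (0.72 log units; beyond the scatter), for hydroxy in place of hydrogen on an aromatic carbon. Compound 3 (`Nc1ccc(-c2cc(=O)c3ccc(O)cc3o2)cc1`) carries amino in place of nitro on an aromatic carbon, para to a large group (amino in place of nitro on an aromatic carbon). Going by the values given here, no measured step covers this exchange. Among the compounds with values here, the step of an at least 5.3-fold lower number from compound 1 to compound 2 (0.72 log units; beyond the scatter) concerns a different group and shows only that a single change can bring a measurable value in this assay, so it is weak guidance. The expected change is therefore modest, toward a lower number: an estimated at least 1.6-fold lower number from compound 1 to compound 3 (0.22 log units; that floor lies within the scatter). For compound 3 the estimated value is 15 ug/mL, with an expected range of 4 ug/mL to 50 ug/mL.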

Compound 3, concentration for half-maximal effect: > 25 ug/mL
Compound 3: a limit, no number; the forecaster's own chance of this, stated with the estimate: 40%; middle value at least 1.6-fold (0.22 log units) away from the limit.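

For the compounds shown here, compound 1 and compound 3 both give only a limit, not a number, so no step between them can be read: the limit of > 25 ug/mL in this assay, at which 2 of the 3 values shown sit. On these data alone, whether amino in place of nitro on an aromatic carbon changes the result in this assay at all remains open.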